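The source may hold more compounds than are shown below. What is called first, only, known or untested is meant among the compounds shown, and "the series" means these compounds.

Measured so far:
compound 1 `COc1ccc(NC(=O)Nn2c(-c3ccccc3)nc3ccccc3c2=O)cc1`: 52%
compound 2 `O=C(Nc1ccc(Cl)cc1)Nn1c(-c2ccccc2)nc2ccccc2c1=O`: 55%

In a functional assay on the whole organism (strain albino) with Mus musculus as the target, at a dose of 100 mg/kg by the intraperitoneal route (on this read-out lower numbers stand for less inhibition and higher numbers for more inhibition at the one dose given (going by the name of the read-out)), compound 2 gives 55%, the higher of the two numbers shown, yet the step of a number 3 percentage points higher from compound 1 to compound 2 (within the scatter) stays within the scatter, so the two compounds are not separated. Compound 3 `O=C(Nc1ccc(F)cc1)Nn1c(-c2ccccc2)nc2ccccc2c1=O` differs from compound 2 by fluoro in place of chloro on an aromatic carbon. Among the compounds with values here, the only measured step that bears on this change is the one from compound 1 to compound 2, an exchange at the same aromatic carbon, and it was within the scatter. Compound 3 is therefore expected to show no step beyond the scatter, a number 1 percentage points lower from compound 2 to compound 3 (within the scatter). Compound 3 is estimated at 54%, within 40% to 68%.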

Compound 3, a percentage reported as inhibition, in the whole organism at one dose (the size of the read-out at that dose, not a potency): 54%
Compound 3: middle estimate and measured number agree at the digits printed; the range from low to high includes it.
By their numbers in this assay, from the lowest: compounds 1, 3 and 2 (each within the scatter of the next).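

In this assay, fluoro in place of chloro gives a number 1 percentage points lower from compound 2 to compound 3 (within the scatter), and fluoro in place of methoxy gives a number 2 percentage points higher from compound 1 to compound 3 (within the scatter). With three groups now compared on this aromatic carbon, methoxy, chloro and fluoro are not separated by this read-out. Nothing measured here offers an explanation for this result. On these data alone, it remains open whether an amine, a carboxylic acid or a longer chain on this carbon would give a step beyond the scatter. As far as these compounds go, whether these three compounds would also stay together at another dose remains open too.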